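A few compounds are considered here, and "the series" means these few. Any claim that something is new, unique, unknown or untested is made for them only; others in the source may bear on it.

Compound 1 `CCCCc1ccc(C)c(=O)n1Cc1ccc(-c2ccccc2-c2nn[nH]n2)cc1` stands as the stronger of the two compounds measured in a functional assay (aorta) for antagonist activity, with Oryctolagus cuniculus as the target; a higher number here means a weaker inhibitor, a lower number a stronger inhibitor: in this assay compound 1 gives 7 nM, the lowest of the two numbers. Compound 2 `CCCCc1ccc(CN(Cc2ccccc2)S(=O)(=O)c2ccccc2)c(=O)n1Cc1ccc(-c2ccccc2-c2nn[nH]n2)cc1` gives 20 nM in this assay, a gap beyond the scatter. Compound 3 `CCCCc1ccc(CN(C)S(C)(=O)=O)c(=O)n1Cc1ccc(-c2ccccc2-c2nn[nH]n2)cc1` differs from compound 1 by methyl(methylsulfonyl)amino in place of hydrogen on a saturated chain carbon bound to an aromatic carbon. Within the data shown here, no measured pair shows this exact change, so the expected step of a 1.7-fold higher number from compound 1 to compound 3 (0.23 log units; within the scatter) is a modest shift toward a weaker inhibitor, close to the edge of the scatter. Compound 3 is therefore expected to give about 12 nM, within a range from 5 nM to 30 nM.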

Compound 3, half-maximal inhibitory concentration: 0.2 nM
The estimate for compound 3 lay 60-fold (1.78 log units) above the measured number; measured number below the stated range.
By their numbers in this assay, from the lowest: compound 3; then compound 1; then compound 2.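

In this assay, placing methyl(methylsulfonyl)amino in place of hydrogen on a saturated chain carbon bound to an aromatic carbon gives a 35-fold lower number from compound 1 to compound 3 (1.54 log units; beyond the scatter) and so moves the compound strongly toward a stronger inhibitor. This position therefore takes a group of 6 heavy atoms with no ring, and activity rises well beyond the scatter. Nothing available explains this gain. Which part of the group carries the step remains open. So does whether a plain amine or a carboxylic acid on the same carbon would give a similar number.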